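Cyclohexylmethyl for Cyclopentyl on the Amide-Type Nitrogen

This account rests on a few compounds, and the source may have more. Where it says the series, first, only, none or still open, it means among the compounds named here.

Measured compounds:
- compound 1, `COc1cc(NC(C)CCCNC(=O)NCc2ccncc2)c2ncccc2c1`: 48000 nM
- compound 2, `CCN(CC)C(=O)NCCCC(C)Nc1cc(OC)cc2cccnc12`: > 100000 nM
- compound 3, `COc1cc(NC(C)CCCNC(=O)NC2CCCC2)c2ncccc2c1`: 25000 nM

In a functional assay on NCI-H460 cells (Homo sapiens), read by MTT assay, with a stated time of 72 h (a higher number here means a weaker inhibitor, a lower number a stronger inhibitor), compound 3 gives 25000 nM, the lowest of the two numbers obtained. Compound 1 sits nearest to it, the difference being a 1.9-fold lower number from compound 1 to compound 3 (0.28 log units; within the scatter), where cyclopentyl replaces (pyridin-4-yl)methyl on the amide-type nitrogen. For compound 2 this assay reports only a limit, > 100000 nM. The step of an at least 4.0-fold lower number from compound 2 to compound 3 (0.60 log units; beyond the scatter), cyclopentylamino in place of diethylamino on the carbonyl carbon, is the clearer one, though it rests on (the limit of > 100000 nM in this assay, at which 1 of the 3 values shown sits).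

Compound 4, `COc1cc(NC(C)CCCNC(=O)NCC2CCCCC2)c2ncccc2c1`, has not yet been measured. It differs from compound 3 by cyclohexylmethyl in place of cyclopentyl on an amide-type nitrogen. Both measured steps that touch this position move from a substituent on the amide-type nitrogen to cyclopentyl; neither shows what a larger ring with a one-carbon link does. The change from compound 1 to compound 3 lay within the scatter, so no step beyond the scatter is expected for compound 4 either, with a slight lean to a lower number, expressed as a 1.4-fold lower number from compound 3 to compound 4 (0.14 log units; within the scatter). Compound 4 is estimated at 18000 nM, between 7000 nM and 50000 nM.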

Compound 4, half-maximal inhibitory concentration: > 100000 nM
Compound 4 ended at the assay's limit; the forecaster's own chance of this, stated with the estimate: 5%; middle value at least 5.5-fold (0.74 log units) from the limit.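

Cyclohexylmethyl in place of cyclopentyl on the amide-type nitrogen brings an at least 4.0-fold higher number from compound 3 to compound 4 (0.60 log units; beyond the scatter), so this position does respond to the group it carries, which the within-scatter step from compound 1 to compound 3 had not shown. With the one-carbon link kept, cyclohexyl in place of pyridin-4-yl brings an at least 2.0-fold higher number from compound 1 to compound 4 (0.31 log units; beyond the scatter), so the link alone does not set the number in this assay. Compound 4 gives only a limit, > 100000 nM, and these steps rest on it: the limit of > 100000 nM in this assay, at which 2 of the 4 values shown sit.

As far as these compounds go, the step between compound 2 and compound 4 joins two limits and cannot be read, and how far compound 4 lies past its limit stays open. Also open, from the compounds shown here alone, is what a cyclohexyl directly on the amide-type nitrogen, or a cyclopentylmethyl group, would give.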